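This account rests on a few compounds, and the source may have more. Where it says the series, first, only, none or still open, it means among the compounds named here.

- Compound 1 `O=C(O)c1cn(C2CC2)c2nc(N3CCC(N4CCCCC4)CC3)c([N+](=O)[O-])cc2c1=O`: > 141000 nM
- Compound 2 `O=C(O)c1cn(C2CC2)c2nc(N3CCC(n4c(=O)[nH]c5cc(Cl)ccc54)CC3)c([N+](=O)[O-])cc2c1=O`: 55500 nM

For the measured compounds named here, in an ADME assay on Vero cells (Chlorocebus sabaeus) for cytotoxicity, read by MTT assay, with a stated time of 72 h (on this read-out higher numbers stand for weaker inhibition and lower numbers for stronger inhibition), compound 2 gives 55500 nM, the only true number available so far. For compound 1, the entry > 141000 nM is a limit of the assay and not a number, as the limit of > 141000 nM in this assay, at which 1 of the 2 values shown sits, records.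

Compound 3 `O=C(O)c1cn(-c2ccc(F)cc2)c2nc(N3CCC(n4c(=O)[nH]c5cc(Cl)ccc54)CC3)c([N+](=O)[O-])cc2c1=O` keeps the rest of compound 2 and carries 4-fluorophenyl in place of cyclopropyl on an aromatic nitrogen.

Going by the values given here, no measured step touches that nitrogen. Among the compounds with values here, the single step available, an at least 2.5-fold lower number from compound 1 to compound 2 (0.40 log units; beyond the scatter), exchanged a different group at a different place, so it offers only a loose guide. In that step, a larger group with an aromatic ring entered and the number in this assay fell. Compound 3 also gains an aromatic ring, so a modest move to a lower number seems more likely than a rise, though one step establishes no rule. The expected change is a 1.9-fold lower number from compound 2 to compound 3 (0.27 log units; within the scatter), which may not clear the scatter by much. Compound 3 is estimated at 30000 nM, with an expected range of 10000 nM to 80000 nM.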

Compound 3, half-maximal inhibitory concentration: 53900 nM
Beside the measured number, compound 3's estimate is 1.8-fold (0.25 log units) below it; the range from low to high includes it.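

In this assay, the exchange of cyclopropyl for 4-fluorophenyl on the aromatic nitrogen gives a 1.0-fold lower number from compound 2 to compound 3 (0.01 log units; within the scatter), so this position tolerates a swap from a three-membered non-aromatic ring to a six-membered aromatic ring of carbon only with no change that can be told from the scatter. An aromatic ring entering the molecule therefore does not in itself go with a lower number in this read-out, and compound 3 goes against what the earlier step on the saturated ring carbon, taken alone, might have suggested. Nothing measured here offers a reason for this flat result.

On these data alone, it remains open whether other groups on this nitrogen, such as an ethyl chain, a tert-butyl group or an unsubstituted phenyl, would stay equally close to compound 2, and the fluorine cannot be judged apart from the phenyl ring, as the two entered together. For the compounds shown here, also open is whether the same exchange would behave alike with the group that compound 1 carries on its saturated ring in place of the one shared by compound 2 and compound 3.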